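The compounds below may be only part of what the source reports. "The series", "measured", "known", "first", "only" and "open" are said of these compounds alone.

Measured compounds:
Compound 1, `N[C@H](C(=O)OCCCOC1(c2ccc(Cl)cc2)c2ccccc2C(=O)N1Cc1ccccc1)c1ccccc1`, gives 14000 nM.
Compound 2, `CC(=O)OCC(C)(C)COC1(c2ccc(Cl)cc2)c2ccccc2C(=O)N1Cc1ccccc1`, gives 38000 nM.

Both compounds were run in a functional assay on HCT-116 cells (Homo sapiens) for inhibition, read by fluorescence, with a stated time of 48 h; on this read-out lower numbers stand for stronger inhibition of growth and higher numbers for weaker inhibition of growth. Compound 2 stands at the highest of the two numbers in this assay; its nearest neighbour, compound 1, gives 14000 nM, a gap that lies beyond the usual scatter. Among the measured compounds shown here, the two compounds differ in more than one place, so their pair tells only what the two values show and gives no single-point step.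

Compound 3, `CC(=O)OCCCOC1(c2ccc(Cl)cc2)c2ccccc2C(=O)N1Cc1ccccc1`, has not yet been measured in this assay. It differs from compound 2 as follows: 2-acetoxyethyl in place of 1-(acetoxymethyl)-1-methylethyl on a saturated chain carbon bound to an oxygen on a saturated carbon. Compound 2 and compound 3 share the same core and the same acetate ester at the end of the chain; only the chain between the two oxygens changes.

For the measured compounds named here, no step between measured compounds bears on this change, so the account carries no measured anchor for it. Compound 3 is expected to lie within the scatter of compound 2, with a 1.3-fold lower number from compound 2 to compound 3 (0.10 log units; within the scatter) as the step that the estimate implies. Compound 3 is estimated at 30000 nM, in the range from 12000 nM to 75000 nM.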

Compound 3, concentration for 50% growth inhibition: 50000 nM
Estimate against measurement, compound 3: 1.7-fold (0.22 log units) below, and the stated range covers the measured number.
By their numbers in this assay, from the lowest: compound 1; then compounds 2 and 3 (each within the scatter of the next).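

In this assay, putting 2-acetoxyethyl in place of 1-(acetoxymethyl)-1-methylethyl on a saturated chain carbon bound to an oxygen on a saturated carbon gives a 1.3-fold higher number from compound 2 to compound 3 (0.12 log units; within the scatter) and so, with the acetate ester kept, the read-out does not tell these two chains apart. Compound 3 also makes the ester end readable as a single change: methyl in place of amino(phenyl)methyl on a carbonyl carbon gives a 3.6-fold higher number from compound 1 to compound 3 (0.55 log units; beyond the scatter) and so, among these three compounds, only the change on the carbonyl carbon moves the number beyond the scatter, towards weaker inhibition of growth. Nothing further is available to explain the size of either step.

The compounds shown leave open whether the step on the carbonyl carbon goes with the amine or with the phenyl ring of amino(phenyl)methyl, as the two always occur together here. They also leave open how a longer chain in place of 3-acetoxypropyl, or a carboxylic acid at its end, would read in this assay and whether the amino(phenyl)methyl ester would read the same on 2-(acetoxymethyl)-2-methylpropyl.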